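Trimethoxyphenyl Replacing Methoxyphenyl on the Shared Core

The source may hold more compounds than are shown below. What is called first, only, known or untested is meant among the compounds shown, and "the series" means these compounds.

Compound 1 `COc1cc(/C=C/C(=O)c2cccc(-n3cc(-c4ccccc4)[nH]c3=O)c2)ccc1O` gives 2010 nM in a functional assay on UACC-62 cells (Homo sapiens) for inhibition; a higher number here means a weaker inhibitor of growth, a lower number a stronger inhibitor of growth.
Compound 2 `COc1ccc(-c2cn(-c3cccc(C(=O)/C=C/c4cc(OC)c(OC)c(OC)c4)c3)c(=O)[nH]2)cc1` gives 2060 nM.
Compound 3 `COc1ccc(-c2cn(-c3cccc(C(=O)/C=C/c4ccc(O)c(OC)c4)c3)c(=O)[nH]2)cc1` gives 3960 nM.

Compound 2 holds the second highest number of the three; its nearest neighbour is compound 1, and the two numbers sit within the scatter of each other. The step of a 1.9-fold higher number from compound 2 to compound 3 (0.28 log units; within the scatter) also lies within the scatter, as does a 2.0-fold higher number from compound 1 to compound 3 (0.29 log units; within the scatter). Compound 4 `COc1cc(/C=C/C(=O)c2cccc(-n3cc(-c4cc(OC)c(OC)c(OC)c4)[nH]c3=O)c2)cc(OC)c1OC` differs from compound 2 by 3,4,5-trimethoxyphenyl in place of 4-methoxyphenyl on an aromatic carbon. Neither measured step touches that position: both concern the chain-bound ring and its substituents, and both are within the scatter, so no step beyond the scatter is expected in this assay from this change. Compound 4 is therefore estimated at 2000 nM, with a range of 700 nM to 6000 nM, an expected step of a 1.0-fold lower number from compound 2 to compound 4 (0.01 log units; within the scatter).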

Compound 4, concentration for 50% growth inhibition: 1870 nM
Estimate against measurement, compound 4: 1.1-fold (0.03 log units) above, within the range that was stated.
By their numbers in this assay, from the lowest: compounds 4, 1, 2 and 3 (each within the scatter of the next, the first and the last beyond it).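

Replacing 4-methoxyphenyl with the larger 3,4,5-trimethoxyphenyl on this aromatic carbon of the five-membered ring leaves the number in this assay within the scatter: a 1.1-fold lower number from compound 2 to compound 4 (0.04 log units; within the scatter). Among these compounds, the earlier compounds showed only a single methoxy change on this aryl group, so the result extends that reading to two further methoxy groups, with 3,4,5-trimethoxyphenyl on the chain. Nothing available bears on why this change has so little effect. On these data alone, what remains open is how an aryl group carrying an amine or a carboxylic acid would behave at this position.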